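Chain end: formyl in place of hydroxy, compound 4 estimate

The source may report more compounds than this note shows. Statements on the series, on what has been measured and on what is new or still open speak of the compounds shown alone.

Measured in an assay on COS-7 cells for displacement of a labelled ligand from Endothelin receptor type B (Sus scrofa); on this read-out lower numbers stand for stronger inhibition and higher numbers for weaker inhibition:
compound 1 `COc1cccc(Sc2c(NS(=O)(=O)c3ccc(C(C)(C)C)cc3)noc2CCCCC=O)c1` gives 20 nM
compound 2 `COc1cccc(Sc2c(NS(=O)(=O)c3ccc(C(C)(C)C)cc3)noc2CCC/C=N/O)c1` gives 85 nM
compound 3 `COc1cccc(Sc2c(NS(=O)(=O)c3ccc(C(C)(C)C)cc3)noc2CCO)c1` gives 430 nM

Compound 3 stands highest of the three numbers in this assay, both gaps beyond the scatter: the nearer is a 5.1-fold higher number from compound 2 to compound 3 (0.70 log units; beyond the scatter), the wider is a 22-fold higher number from compound 1 to compound 3 (1.33 log units; beyond the scatter).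

Compound 4 `COc1cccc(Sc2c(NS(=O)(=O)c3ccc(C(C)(C)C)cc3)noc2CCC=O)c1` is the next step from compound 3: formyl in place of hydroxy on a saturated chain carbon, two bonds along the chain from an aromatic carbon. The chain grows by one carbon and ends in formyl, where compound 1 ends in formyl after a longer chain. The measured step that bears most directly is a 22-fold higher number from compound 1 to compound 3 (1.33 log units; beyond the scatter), in which hydroxy replaced 2-formylethyl and the number rose by a large amount; the change to compound 4 runs the other way but covers only part of that difference in chain length. The step of a 5.1-fold higher number from compound 2 to compound 3 (0.70 log units; beyond the scatter) points the same way with a modest size. A lowering of intermediate size is therefore expected, roughly a 4.8-fold lower number from compound 3 to compound 4 (0.68 log units; beyond the scatter). For compound 4 the expected value in this assay is 90 nM, with a range from 30 nM to 270 nM.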

Compound 4, half-maximal inhibitory concentration: 500 nM
Estimate against measurement, compound 4: 5.6-fold (0.74 log units) below, and the stated range ends below it.
By their numbers in this assay, from the lowest: compound 1; then compound 2; then compounds 3 and 4 (each within the scatter of the next).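

In this assay, formyl in place of hydroxy at this chain end leaves the number unchanged within the scatter (a 1.2-fold higher number from compound 3 to compound 4 (0.07 log units; within the scatter)), so on this short chain the formyl end does not bring the low number of compound 1. The same end group on the longer chain differs widely (a 25-fold higher number from compound 1 to compound 4 (1.40 log units; beyond the scatter)), which places the large difference with 2-formylethyl against formyl at this position rather than with the end group alone; the oxime-ended chain also stays clear of the short formyl chain (a 5.9-fold higher number from compound 2 to compound 4 (0.77 log units; beyond the scatter)). Nothing available explains why the extra chain length goes with the lower number.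

Open, from the compounds shown here alone, is whether a hydroxy end on the longer chain would match the formyl end of compound 1. Also open, going by these compounds, is how a carboxylic acid or an amine at the chain end would read.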